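The compounds below may be only part of what the source reports. "The series", "measured", "known", "first", "only" and "open" are said of these compounds alone.

Compound 1 `CC/N=C(/NC#N)NCCCCn1nc(-c2ccccc2)ccc1=O`: 58.8%
Compound 2 `N/C(S)=N/CCCCn1nc(-c2ccccc2)ccc1=O`: 72%

Both compounds were tested in a functional assay on the whole organism with Rattus norvegicus as the target, at a dose of 100 mg/kg; on this read-out higher numbers stand for more inhibition at the one dose given (going by the name of the read-out) and lower numbers for less inhibition. Compound 1 gives 58.8%, the lower of the two numbers. Going by the values given here, its only neighbour is compound 2, and the step is a number 13.2 percentage points higher from compound 1 to compound 2 (beyond the scatter), which came from a group of 4 heavy atoms (1 carbon, 2 nitrogen, 1 sulfur; no ring) taking the place of a group of 8 heavy atoms (4 carbon, 4 nitrogen; no ring), on a saturated chain carbon.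

Compound 3 `O=c1ccc(-c2ccccc2)nn1CCCCNC(=S)Nc1ccccc1` has not been measured in this assay. Compared with compound 1 the change is a group of 9 heavy atoms (7 carbon, 1 nitrogen, 1 sulfur; one six-membered aromatic ring of carbon only) in place of a group of 7 heavy atoms (4 carbon, 3 nitrogen; no ring), on an amine nitrogen. As in the measured step, the part that leaves carries the triple bond and several nitrogens while a sulfur-bearing group enters, so the step from compound 1 to compound 2 is the one that bears on this change; that step was modest and beyond the scatter. Among the compounds with values here, for compound 3 a rise of about a number 9.2 percentage points higher from compound 1 to compound 3 (within the scatter) is therefore expected, with the aromatic ring of the entering group adding uncertainty, since no measured compound carries it. Compound 3 is estimated at 68%, within 50% to 84%.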

Compound 3, a percentage reported as inhibition, in the whole organism at one dose (the size of the read-out at that dose, not a potency): 38.4%
Beside the measured number, compound 3's estimate is 29.6 percentage points above it; measured number below the stated range.
By their numbers in this assay, from the lowest: compound 3; then compound 1; then compound 2.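

On the amine nitrogen at the end of the chain, the group that enters can take the number down as well as up: in this assay, exchanging the open-chain, nitrile-bearing group for one with a six-membered aromatic ring of carbon only gives a step of a number 20.4 percentage points lower from compound 1 to compound 3 (beyond the scatter). The earlier step, a number 13.2 percentage points higher from compound 1 to compound 2 (beyond the scatter), went the other way, so a sulfur-bearing group does not by itself go with more inhibition: compound 2 and compound 3 both carry sulfur, yet their steps from compound 1 have opposite signs. No accompanying measurement explains why the aromatic ring-bearing group gives the lower number.

These few compounds cannot separate the effect of the aromatic ring from that of the rest of the entering group, and a methyl group or a benzyl group in the ring's place would be needed to tell how far the result belongs to the ring itself. The results also come from a single dose, so they leave open how the compounds would compare across a range of doses.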